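Bicyclic amine replacement on the lactam nitrogen: factor X series

This account rests on a few compounds, and the source may have more. Where it says the series, first, only, none or still open, it means among the compounds named here.

Measured so far:
compound 1 `O=C1[C@@H](NS(=O)(=O)c2ccc(-c3ccon3)s2)CCN1Cc1cc2cc[nH]cc-2n1`: 49%
compound 2 `O=C1[C@@H](NS(=O)(=O)c2ccc(-c3ccon3)s2)CCN1CCNc1ccncc1`: 22%
compound 3 `O=C1[C@@H](NS(=O)(=O)c2ccc(-c3ccncc3)s2)CCN1CCNc1ccncc1`: 41%

In an assay on isolated protein for inhibition of coagulation factor X (Oryctolagus cuniculus), tested at 1 uM (a lower number here means less inhibition, a higher number more inhibition at the concentration tested (going by the name of the read-out)), compound 2 gives 22%, the lowest of the three numbers. Two single changes from compound 2 are measured. Among the measured compounds shown here, the first is a group of 9 heavy atoms (7 carbon, 2 nitrogen; one five-membered aromatic ring with 1 hetero atom, one six-membered aromatic ring with 1 hetero atom) in place of a group of 8 heavy atoms (6 carbon, 2 nitrogen; one six-membered aromatic ring with 1 hetero atom), on a saturated chain carbon bound to an amide-type nitrogen in a ring, giving compound 1, a step of a number 27 percentage points higher from compound 2 to compound 1 (beyond the scatter). The second is pyridin-4-yl in place of 1,2-oxazol-3-yl on an aromatic carbon, giving compound 3, a step of a number 19 percentage points higher from compound 2 to compound 3 (beyond the scatter). Compound 1 and compound 3 lie within the scatter of each other, so no order between them is claimed.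

Compound 4 `O=C1[C@@H](NS(=O)(=O)c2ccc(-c3ccncc3)s2)CCN1Cc1cc2cc[nH]cc-2n1` is not yet measured. It differs from compound 3 by a group of 9 heavy atoms (7 carbon, 2 nitrogen; one five-membered aromatic ring with 1 hetero atom, one six-membered aromatic ring with 1 hetero atom) in place of a group of 8 heavy atoms (6 carbon, 2 nitrogen; one six-membered aromatic ring with 1 hetero atom), on a saturated chain carbon bound to an amide-type nitrogen in a ring. This is the same kind of change as from compound 2 to compound 1; the two place descriptions agree word for word. The cores differ by pyridin-4-yl in place of 1,2-oxazol-3-yl on an aromatic carbon.

For the measured compounds named here, the one measured example of this change gives a number 27 percentage points higher from compound 2 to compound 1 (beyond the scatter). Resting on that step and on the value of compound 3, 41%, compound 4 is expected to show a step of a number 25 percentage points higher from compound 3 to compound 4 (beyond the scatter) in this assay. Going by the values given here, the estimate for compound 4 is 66%, with a likely range of 48% to 82%, since only one example of the change is available.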

Compound 4, a percentage reported as inhibition, at one concentration (the size of the read-out at that concentration, not a potency): 50%
Beside the measured number, compound 4's estimate is 16 percentage points above it; measured number inside the range.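

On the core of compound 3, the change on the saturated chain carbon bound to the amide-type nitrogen gives a number 9 percentage points higher from compound 3 to compound 4 (within the scatter) in this assay, so the step does not carry over at the same size from one core to the other: the same change on two cores in this assay, a number 27 percentage points higher (beyond the scatter) from compound 2 to compound 1 and a number 9 percentage points higher (within the scatter) from compound 3 to compound 4, 18 percentage points apart, beyond the scatter of two such steps

The exchange of 1,2-oxazol-3-yl for pyridin-4-yl likewise depends on the other end of the molecule, with a number 1 percentage points higher from compound 1 to compound 4 (within the scatter) in this assay: the same change on two cores in this assay, a number 19 percentage points higher (beyond the scatter) from compound 2 to compound 3 and a number 1 percentage points higher (within the scatter) from compound 1 to compound 4, 18 percentage points apart, beyond the scatter of two such steps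

These results show that the two changes do not simply add in this set of four compounds, but they rest on one pair of cores and do not show why the steps differ or how either change behaves on a further core.

Still open, going by these compounds, is whether phenyl in place of pyridin-4-yl on the aromatic carbon, or a longer chain ending in an amine in place of the group on the saturated chain carbon, would follow the same pattern. A percentage at one concentration also leaves the relative potency of these compounds open.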